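Position of the hydroxyphenyl and oral exposure in mice

The source may hold more compounds than are shown below. What is called first, only, known or untested is meant among the compounds shown, and "the series" means these compounds.

Among the compounds with values here, in an ADME assay on the whole organism for pharmacokinetics, with Mus musculus as the target, at a dose of 10 mg/kg by the oral route (on this read-out lower numbers stand for lower exposure and higher numbers for higher exposure at the dose given), compound 1 `CC1=C(c2ccc(O)cc2)C(c2ccc(OC[C@H](C)N3CC[C@@H](C)C3)cc2)Oc2cc(O)ccc21` gives 120 ng.h/mL, the lowest of the three numbers so far; compound 2 `CC1=C(c2cccc(F)c2)C(c2ccc(OC[C@H](C)N3CC[C@@H](C)C3)cc2)Oc2ccc(O)cc21` gives 350 ng.h/mL and compound 3 `CC1=C(c2cccc(O)c2)C(c2ccc(OC[C@H](C)N3CC[C@@H](C)C3)cc2)Oc2ccc(O)cc21` gives 590 ng.h/mL. Within the data shown here, the one step between neighbours differing in a single place is a 1.7-fold higher number from compound 2 to compound 3 (0.23 log units; within the scatter), and it does not touch the change considered here. Compound 4 `CC1=C(c2cccc(O)c2)C(c2ccc(OC[C@H](C)N3CC[C@@H](C)C3)cc2)Oc2cc(O)ccc21` differs from compound 1 by 3-hydroxyphenyl in place of 4-hydroxyphenyl on a double-bonded ring carbon. Compound 3 carries the same 3-hydroxyphenyl but also differs from compound 1 in a second place, so the gap between those two values cannot be laid to either change alone. With nothing bearing directly on this change, no movement beyond the scatter is expected, and compound 4 is estimated at 200 ng.h/mL, between 80 ng.h/mL and 500 ng.h/mL, which would mean an expected step of a 1.7-fold higher number from compound 1 to compound 4 (0.22 log units; within the scatter).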

Compound 4, area under the concentration-time curve: 50 ng.h/mL
Estimate against measurement, compound 4: 4.0-fold (0.60 log units) above; the whole stated range lies above it.
By their numbers in this assay, from the lowest: compound 4; then compound 1; then compounds 2 and 3 (each within the scatter of the next).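

With the rest of the molecule fixed, moving the hydroxy group from 4-hydroxyphenyl to 3-hydroxyphenyl on the double-bonded ring carbon gives a 2.4-fold lower number from compound 1 to compound 4 (0.38 log units; beyond the scatter) in this assay, so the hydroxy placement on this ring alone shifts exposure. The 3-hydroxyphenyl does not by itself set the level: compound 4 gives 50 ng.h/mL, while compound 3, with the core hydroxy placed elsewhere, gives 590 ng.h/mL. No supporting data explain this shift.

Going by these compounds, it remains open whether the same drop holds with the core hydroxy as in compound 3. Also open, on these data alone, is how a methoxy group or an amine would behave on this phenyl ring.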